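Amide nitrogen substituents on the shared core, paw edema read-out

A few compounds are considered here, and "the series" means these few. Any claim that something is new, unique, unknown or untested is made for them only; others in the source may bear on it.

Measured so far:
compound 1 `CNC(=O)c1nc(-c2cc(OC)c(OC)c(OC)c2)n(-c2ccc(OC)cc2)n1` gives 56%
compound 2 `COc1ccc(-n2nc(C(=O)Nc3ccccc3OC)nc2-c2cc(OC)c(OC)c(OC)c2)cc1` gives 52%
compound 3 `COc1ccc(-n2nc(C(=O)Nc3ccc(C)cc3)nc2-c2cc(OC)c(OC)c(OC)c2)cc1` gives 38%

In a functional assay on the whole organism for inhibition, with Rattus norvegicus as the target, read by paw edema, with stated times of 30 min and 1 h, at a dose of 0.28 mmol/kg by the oral route (on this read-out higher numbers stand for more inhibition at the one dose given (going by the name of the read-out) and lower numbers for less inhibition), compound 1 stands highest of the three, though its gap to compound 2, a number 4 percentage points lower from compound 1 to compound 2 (within the scatter), is within the scatter; only compound 3 sits clearly lower, a number 18 percentage points lower from compound 1 to compound 3 (beyond the scatter). Compound 4 `COc1ccc(-n2nc(C(=O)Nc3ccccc3C)nc2-c2cc(OC)c(OC)c(OC)c2)cc1` is not yet measured. It differs from compound 1 by 2-methylphenyl in place of methyl on an amide-type nitrogen. Both measured steps off compound 1 bear on this: the 2-methoxyphenyl step barely moved the number, the 4-methylphenyl step lowered it modestly. A small loss, possibly within the scatter, is therefore expected, a number 9 percentage points lower from compound 1 to compound 4 (within the scatter). Compound 4 is estimated at 47%, with a range from 35% to 58%.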

Compound 4, a percentage reported as inhibition, in the whole organism at one dose (the size of the read-out at that dose, not a potency): 19%
The estimate for compound 4 lay 28 percentage points above the measured number; measured number outside the range, below it.
By their numbers in this assay, from the lowest: compound 4; then compound 3; then compounds 2 and 1 (each within the scatter of the next).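

Aryl groups on the amide-type nitrogen do not behave alike: 2-methylphenyl in place of methyl gives a number 37 percentage points lower from compound 1 to compound 4 (beyond the scatter) as a large step, which the near-silent 2-methoxyphenyl change in compound 2 gave no sign of. The place of the methyl on the aryl group counts, with a number 19 percentage points lower from compound 3 to compound 4 (beyond the scatter) as a modest step. Methyl in place of methoxy on the same aromatic carbon gives a number 33 percentage points lower from compound 2 to compound 4 (beyond the scatter) as a large step.

No measurement at hand accounts for these steps. Open, as far as these compounds go, is how a longer alkyl chain, such as propyl, or a benzyl group on this nitrogen would compare with methyl and with the aryl groups.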